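Acetyl in place of allyl on the shared core

This account rests on a few compounds, and the source may have more. Where it says the series, first, only, none or still open, it means among the compounds named here.

In a functional assay on MCF7 cells (Homo sapiens) for inhibition (a lower number here means a stronger inhibitor, a higher number a weaker inhibitor), compound 1 (`CCCCCCCC[C@@]1(C)SC(O)=CC1=O`) gives 12.6 ug/mL. Compound 2 (`C=CCC1=C(O)S[C@](C)(CCCCCCCC)C1=O`) gives 34.8 ug/mL, the higher of the two numbers and so the weaker inhibitor of the pair. Among the compounds with values here, the only measured step is a 2.8-fold higher number from compound 1 to compound 2 (0.44 log units; beyond the scatter), a modest change for allyl in place of hydrogen on a double-bonded ring carbon.

Compound 3 (`CCCCCCCC[C@@]1(C)SC(O)=C(C(C)=O)C1=O`) keeps the core of compound 2 and carries acetyl in place of allyl on a double-bonded ring carbon. The measured step bears on this only indirectly, since it shows that the number in this assay moves with a change at this same place. No measurement with acetyl exists yet. Within the data shown here, a small move toward compound 1 is therefore expected, and no large step. The expected change is a 1.5-fold lower number from compound 2 to compound 3 (0.16 log units; within the scatter). For compound 3 the estimate is 24 ug/mL, with an expected range of 9 ug/mL to 65 ug/mL.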

Compound 3, half-maximal inhibitory concentration: 12 ug/mL
Compound 3: the middle estimate sits 2.0-fold (0.30 log units) above what was measured; the measured number falls inside the stated range.
By their numbers in this assay, from the lowest: compounds 3 and 1 (each within the scatter of the next); then compound 2.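

At the double-bonded ring carbon, the number depends on which group is present and not simply on whether the position is substituted: in this assay, acetyl in place of allyl gives a 2.9-fold lower number from compound 2 to compound 3 (0.46 log units; beyond the scatter), while acetyl in place of hydrogen gives a 1.1-fold lower number from compound 1 to compound 3 (0.02 log units; within the scatter). This assay does not separate acetyl from hydrogen here, and of the three groups shown, only allyl stands apart. No measurement bearing on the reason for the difference between allyl and acetyl is available.

As far as these compounds go, whether any group at this position can give a number clearly lower than hydrogen remains open, with an amine, a carboxylic acid or a propyl group among the untested possibilities here. From the compounds shown here alone, all three compounds keep the methyl group and the group of 8 heavy atoms, so it also remains open whether the allyl-to-acetyl difference holds when either is replaced.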